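Rearranging Fluorines and Nitro on One Aryl Ring

A few compounds are considered here, and "the series" means these few. Any claim that something is new, unique, unknown or untested is made for them only; others in the source may bear on it.

Compound 1 `Nc1nc(N)c(CCCNc2cc(F)c(F)cc2[N+](=O)[O-])c(O)n1`: 97000 nM
Compound 2 `COC(=O)c1ccc(CN(CCCc2c(N)nc(N)nc2O)c2cc(F)c(F)cc2[N+](=O)[O-])cc1`: 66000 nM
Compound 3 `COC(=O)c1ccc(CN(CCCc2c(N)nc(N)nc2O)c2cc(F)c([N+](=O)[O-])cc2[N+](=O)[O-])cc1`: 4300 nM

All three were tested in a functional assay on CCRF-CEM cells (Homo sapiens) for cytotoxicity, in the absence of a further agent; a higher number here means a weaker inhibitor, a lower number a stronger inhibitor. Compound 2 gives the second highest of the three numbers; its nearest neighbour is compound 1, with a 1.5-fold lower number from compound 1 to compound 2 (0.17 log units; within the scatter), and its furthest is compound 3, with a 15-fold lower number from compound 2 to compound 3 (1.19 log units; beyond the scatter).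

Compound 4 `COC(=O)c1ccc(CN(CCCc2c(N)nc(N)nc2O)c2ccc([N+](=O)[O-])c(F)c2F)cc1` keeps every atom of compound 2 but joins them differently: 2,3-difluoro-4-nitrophenyl in place of 4,5-difluoro-2-nitrophenyl on an amine nitrogen. For the measured compounds named here, no measured step moves groups around this ring. Going by the values given here, the only step that touches the ring, a 15-fold lower number from compound 2 to compound 3 (1.19 log units; beyond the scatter), swaps one group for another rather than moving them, so it offers no direct guide. With nothing to point either way, a step within the scatter is expected, a 1.1-fold higher number from compound 2 to compound 4 (0.03 log units; within the scatter). Compound 4 is therefore estimated at 70000 nM, plausibly between 20000 nM and 250000 nM.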

Compound 4, half-maximal inhibitory concentration: 55000 nM
The estimate for compound 4 lay 1.3-fold (0.10 log units) above the measured number, within the range that was stated.
By their numbers in this assay, from the lowest: compound 3; then compounds 4, 2 and 1 (each within the scatter of the next).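

Rearranging the same atoms on this ring, with 2,3-difluoro-4-nitrophenyl in place of 4,5-difluoro-2-nitrophenyl on the amine nitrogen, gives a 1.2-fold lower number from compound 2 to compound 4 (0.08 log units; within the scatter) in this assay. So, for this pair, moving the nitro group and the two fluorines leaves the number within the scatter, whereas the earlier ring step replaced one group with another. No measurement here explains this result.

Still open, from the compounds shown here alone, is whether the two nitro groups of compound 3 would tolerate the same rearrangement, and what a nitrile or an amine in place of the nitro group would do.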